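A few compounds are considered here, and "the series" means these few. Any claim that something is new, unique, unknown or untested is made for them only; others in the source may bear on it.

Within the data shown here, compound 2, with the structure `CC(C)c1ccc(-c2nc(CNc3ccc(C(=O)NO)cc3)n(-c3ccccc3)n2)cc1`, stands lowest of the two numbers so far in an assay on Sf9 cells for inhibition of protein deacetylase HDAC6 (Homo sapiens), read by fluorescence, with a stated time of 40 min, tested at 100 nM; a higher number here means more inhibition at the concentration tested (going by the name of the read-out), a lower number less inhibition: compound 2 gives 27.6%. Its nearest neighbour is compound 1, `Cc1ccccc1-c1nc(CNc2ccc(C(=O)NO)cc2)n(-c2ccccc2)n1`, which in this assay gives 53.2%. Among the measured compounds shown here, the one measured step that connects them, a change of a number 25.6 percentage points lower from compound 1 to compound 2 (beyond the scatter), arises from the 4-isopropylphenyl replacing the 2-methylphenyl on an aromatic carbon of the shared core.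

Compound 3, `Cc1ccc(-c2nc(CNc3ccc(C(=O)NO)cc3)n(-c3ccccc3)n2)o1`, is not yet measured. It differs from compound 2 in one place: 5-methylfuran-2-yl in place of 4-isopropylphenyl on an aromatic carbon. No measured step involves a 5-methylfuran-2-yl group, so the one step shown bears on this change only loosely: it shows that the group on this aromatic carbon matters, with the larger 4-isopropylphenyl sitting beyond the scatter below the 2-methylphenyl. The 5-methylfuran-2-yl is a smaller group than the one it replaces, and the expectation is therefore a step of a number 12.4 percentage points higher from compound 2 to compound 3 (beyond the scatter) in this assay for compound 3, upward, though with wide uncertainty. In this assay, compound 3 is estimated at 40%, expected to fall between 15% and 65%.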

Compound 3, a percentage reported as inhibition, at one concentration (the size of the read-out at that concentration, not a potency): 60.7%
Compound 3: the middle estimate sits 20.7 percentage points below what was measured; measured number inside the range.
By their numbers in this assay, from the lowest: compound 2; then compounds 1 and 3 (each within the scatter of the next).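

In this assay, replacing the 4-isopropylphenyl with the 5-methylfuran-2-yl on this aromatic carbon gives a number 33.1 percentage points higher from compound 2 to compound 3 (beyond the scatter), so compound 2 now stands apart from two differently built neighbours rather than from one. The step of a number 7.5 percentage points higher from compound 1 to compound 3 (within the scatter) leaves compound 1 and compound 3 indistinguishable, which shows that this position accepts a five-membered aromatic ring with one oxygen as well as a six-membered aromatic ring of carbon only, with no loss of inhibition at the concentration tested. Nothing available explains why the 4-isopropylphenyl stands apart from these two groups.

The compounds shown leave open whether the low number of compound 2 goes with the isopropyl group itself, a question that an unsubstituted phenyl or a 4-methylphenyl at this position would address, and whether the methyl on the furan contributes anything, which a plain furan-2-yl would test. They also leave open how a saturated ring such as cyclohexyl or a basic group such as an aminomethyl-substituted phenyl would fare here, and these single-concentration percentages give no potency for any of the compounds.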